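Working notes: acetoxy to methoxy, compound 1 to compound 4

The compounds below may be only part of what the source reports. "The series", "measured", "known", "first", "only" and "open" are said of these compounds alone.

- compound 1 `CC(=O)Oc1ccccc1/C=C/c1nc2ccccc2c(=O)[nH]1` gives 17200 nM
- compound 2 `COc1ccc(OC)c(Nc2nc(/C=C/c3ccccc3OC(C)=O)nc3ccccc23)c1` gives > 25000 nM as a limit
- compound 3 `CC(=O)Oc1ccc(/C=C/c2nc3ccccc3c(=O)[nH]2)c(OC(C)=O)c1` gives 23000 nM

For the measured compounds named here, in a functional assay on HCT-116 cells (Homo sapiens) for antiproliferative activity, with a stated time of 72 h (a lower number here means a stronger inhibitor, a higher number a weaker inhibitor), compound 1 gives 17200 nM and has only one numeric neighbour, within the scatter: a 1.3-fold higher number from compound 1 to compound 3 (0.13 log units; within the scatter). Going by the values given here, compound 2 is a limit only, > 25000 nM, and gives no step. Next comes compound 4 `COc1ccccc1/C=C/c1nc2ccccc2c(=O)[nH]1`, with methyl in place of acetyl on an oxygen on an aromatic ring. Among the compounds with values here, no measured step makes this change. The closest evidence is the added acetoxy in a 1.3-fold higher number from compound 1 to compound 3 (0.13 log units; within the scatter), so no step beyond the scatter is expected in this assay. The estimated step is a 1.2-fold higher number from compound 1 to compound 4 (0.07 log units; within the scatter). Compound 4 is expected at 20000 nM, with an estimated range from 9000 nM to 45000 nM.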

Compound 4, half-maximal inhibitory concentration: 1460 nM
Compound 4: the middle estimate sits 14-fold (1.14 log units) above what was measured; the whole stated range lies above it.
By their numbers in this assay, from the lowest: compound 4; then compounds 1 and 3 (each within the scatter of the next). At a limit, above all of these: compound 2.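

In this assay, for the compounds shown here, the step of a 12-fold lower number from compound 1 to compound 4 (1.07 log units; beyond the scatter) is the first to lie beyond the scatter, and it places the sensitive change on the oxygen on an aromatic ring, where acetoxy gives way to methoxy. The earlier step, an added acetoxy on an aromatic carbon, stayed within the scatter. Nothing available here accounts for the size of this step.

Still open, as far as these compounds go, is whether a free hydroxy, a longer chain such as ethoxy, or an amine at this place would hold the lower number. Also open, from the compounds shown here alone, is whether methoxy in place of both acetoxy groups of compound 3 would bring a similar step.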